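This account rests on a few compounds, and the source may have more. Where it says the series, first, only, none or still open, it means among the compounds named here.

Among the compounds with values here, in a functional assay on C6 cells (Rattus norvegicus) for cytotoxicity, read by MTT assay, with a stated time of 24 h, tested at 6 ug/mL (on this read-out lower numbers stand for a stronger effect and higher numbers for a weaker effect at the one concentration tested), compound 2 `COc1ccc(-c2cs/c(=N/NC(=O)CSc3nnc(C)s3)n2-c2ccccc2)cc1` gives 57.9%, the lowest of the two numbers measured so far. Compound 1 `Cc1nnc(SCC(=O)N/N=c2/scc(-c3ccccc3)n2-c2ccccc2)s1` gives 72.4%, and the step of a number 14.5 percentage points lower from compound 1 to compound 2 (beyond the scatter) went along with methoxy in place of hydrogen on an aromatic carbon. Compound 3 `Cc1ccc(-c2cs/c(=N/NC(=O)CSc3nnc(C)s3)n2-c2ccccc2)cc1` differs from compound 2 by methyl in place of methoxy on an aromatic carbon. Within the data shown here, no measured step exchanges methoxy for methyl, so the single recorded step bears only loosely on this change, and the expected step of a number 5.1 percentage points higher from compound 2 to compound 3 (within the scatter) is small, quite possibly within the scatter. Compound 3 is therefore expected to give about 63%, within a range from 46% to 80%.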

Compound 3, a percentage reported as activity, at one concentration (the size of the read-out at that concentration, not a potency): 65.9%
Compound 3: middle estimate off by 2.9 percentage points, on the low side; low and high end bracket the measured number.
By their numbers in this assay, from the lowest: compounds 2, 3 and 1 (each within the scatter of the next, the first and the last beyond it).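

In this assay, swapping methoxy for methyl on this aromatic carbon gives a number 8 percentage points higher from compound 2 to compound 3 (within the scatter), so the two groups cannot be told apart here. Methyl cannot be told apart from hydrogen either, with a number 6.5 percentage points lower from compound 1 to compound 3 (within the scatter), even though methoxy and hydrogen do differ beyond the scatter, so methyl fits with both ends of that one clear step. Nothing measured on these compounds explains this result.

Going by these compounds, whether an amine or a carboxylic acid at this place would shift the read-out further remains open. So does whether a longer chain, such as ethoxy in place of methoxy, would do so.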